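This account rests on a few compounds, and the source may have more. Where it says the series, first, only, none or still open, it means among the compounds named here.

Compound 2 `CCS(=O)(=O)Nc1cccc(NC2=NCCN2)c1` is one of two compounds whose numbers are already in hand. Among the compounds with values here, in an assay on isolated protein for binding affinity to Alpha-1D adrenergic receptor (Rattus norvegicus), read by radioligand binding (a higher number here means a weaker inhibitor, a lower number a stronger inhibitor), compound 2 gives 355 nM, the lowest of the two numbers known so far. Compound 1 `CS(=O)(=O)Nc1cccc2c1CCCCC2c1c[nH]cn1` lies well away from it, beyond the scatter of repeated measurements: in this assay compound 1 gives 2510 nM. Compound 3 `CCS(=O)(=O)Nc1cccc(Sc2c[nH]cn2)c1` has not yet been measured. Compound 3 differs from compound 2 in a single place: a group of 6 heavy atoms (3 carbon, 2 nitrogen, 1 sulfur; one five-membered aromatic ring with 2 hetero atoms) in place of a group of 6 heavy atoms (3 carbon, 3 nitrogen; one five-membered non-aromatic ring with 2 hetero atoms), on an aromatic carbon. The incoming group gives compound 3 a five-membered aromatic ring with 2 hetero atoms, the same kind of ring that compound 1 carries, and compound 1 sits far above compound 2 in this assay. Within the data shown here, no step between two measured compounds is known that would show this change directly, so the expectation rests on that resemblance alone. The step of a 5.6-fold higher number from compound 2 to compound 3 (0.75 log units; beyond the scatter) is expected to point toward a weaker inhibitor and to go beyond the scatter. For compound 3 the estimate in this assay is 2000 nM, with an expected range from 500 nM to 8000 nM.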

Compound 3, inhibition constant: < 10000 nM
Compound 3: a limit, no number; the forecaster's own chance of this, stated with the estimate: 10%; the middle value does not contradict the limit.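

In this assay, within the data shown here, compound 3 gives < 10000 nM as a limit and not a number, so no step from compound 2 to compound 3 can be read. The compounds shown leave open whether the (1H-imidazol-4-yl)sulfanyl group of compound 3 gives a weaker or a stronger inhibitor than the group it replaces in compound 2.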